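A few compounds are considered here, and "the series" means these few. Any claim that something is new, unique, unknown or untested is made for them only; others in the source may bear on it.

Measured so far in a functional assay on DU-145 cells (Homo sapiens) for cytotoxicity, read by MTT assay, with a stated time of 48 h; a higher number here means a weaker inhibitor, a lower number a stronger inhibitor:
- compound 1 `COc1cc(CN(C(=O)Nc2ccc(C#N)cc2)n2cnnc2)cc(OC)c1OC` gives 20600 nM
- compound 2 `CCCCCCCCCNC(=O)N(Cc1cc(OC)ccc1OC)n1cnnc1` gives > 50000 nM
- compound 3 `N#Cc1ccc(CN(C(=O)Nc2cc(C(F)(F)F)cc(C(F)(F)F)c2)n2cnnc2)cc1` gives 11800 nM

Compound 1 and compound 3 both give a number in this assay. Compound 2 does not: its result is a limit of the assay, (the limit of > 50000 nM in this assay, at which 1 of the 3 values shown sits), and not a measured value. Compound 2 therefore stands at the weakest end of what this assay can report, and its true potency may lie anywhere beyond that edge.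

Compound 4 `COc1ccc(OC)c(CN(C(=O)NC2CCCCC2)n2cnnc2)c1` has not yet been measured. It differs from compound 2 in one place: cyclohexyl in place of nonyl on an amide-type nitrogen. Everything else in the molecule stays the same.

Among the measured compounds shown here, no pair of measured compounds differs in just this way, so there is no measured step to lean on. The starting point is a limit, which means a small change in either direction would stay hidden, and only a clear gain in potency would show up as a number. The step of an at least 1.1-fold lower number from compound 2 to compound 4 (0.04 log units; that floor lies within the scatter) is expected to be modest, if there is one at all, and not beyond the usual scatter. Compound 4 is therefore estimated at about 45000 nM, with a range from 20000 nM to 100000 nM, and a real chance that this assay again reports only a limit.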

Compound 4, half-maximal inhibitory concentration: 29800 nM
Compound 4: the middle estimate sits 1.5-fold (0.18 log units) above what was measured, within the range that was stated.
By their numbers in this assay, from the lowest: compounds 3, 1 and 4 (each within the scatter of the next, the first and the last beyond it). At a limit, above all of these: compound 2.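

In this assay, cyclohexyl in place of nonyl on an amide-type nitrogen gives a result that can be read as a number, which shows that a change at this position can bring a compound into the range the assay reports. Compound 2 remains a limit and not a measured value, so the change can be sized from one side only: the limit of > 50000 nM in this assay, at which 1 of the 4 values shown sits. The change amounts to an at least 1.6-fold lower number from compound 2 to compound 4 (0.22 log units; that floor lies within the scatter); the true step may be larger, but this floor alone does not establish a gain beyond the scatter, and the swap replaces a chain with a ring and also lowers the carbon count, so these two differences cannot be separated.

A straight hexyl chain at this position would help to show whether the ring itself matters or whether a shorter chain would give a similar result. On these data alone, it also remains open how a polar group would fare here, for example an amine or a carboxylic acid attached to the cyclohexyl ring, or whether a phenyl ring in place of cyclohexyl would change the number.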